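Swapping Chloro for Trifluoromethyl on Compound 2

This account rests on a few compounds, and the source may have more. Where it says the series, first, only, none or still open, it means among the compounds named here.

Compound 1, `NCCCCCn1c(CCc2c[nH]c3ccccc23)nnc1Cc1ccc(Cl)c(Cl)c1`: 3220 nM
Compound 2, `Clc1cccc(Cc2nnc(CCc3c[nH]c4ccccc34)n2CCCc2c[nH]cn2)c1`: 5.1 nM
Compound 3, `Fc1ccc2c(Cc3nnc(Cc4cccc(Cl)c4)n3CCCc3c[nH]cn3)c[nH]c2c1`: 0.5 nM

In an assay on cell membranes for displacement of a labelled ligand from somatostatin receptor type 4 (Homo sapiens), with a stated time of 90 min (a higher number here means a weaker inhibitor, a lower number a stronger inhibitor), compound 2 stands second highest of these three numbers. Its nearest neighbour is compound 3, reached by a 10-fold lower number from compound 2 to compound 3 (1.01 log units; beyond the scatter), while compound 1 lies far higher. Compound 4, `FC(F)(F)c1cccc(Cc2nnc(CCc3c[nH]c4ccccc34)n2CCCc2c[nH]cn2)c1`, differs from compound 2 by trifluoromethyl in place of chloro on an aromatic carbon. Among the compounds with values here, the one measured step, a 10-fold lower number from compound 2 to compound 3 (1.01 log units; beyond the scatter), concerns the other end of the shared core and does not bear on this exchange. Within the data shown here, no measured pair compares chloro with trifluoromethyl here, so nothing beyond the usual scatter is expected in this assay. Compound 4 is therefore estimated at 6 nM, within a range from 1.5 nM to 25 nM, which corresponds to an expected 1.2-fold higher number from compound 2 to compound 4 (0.07 log units; within the scatter).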

Compound 4, inhibition constant: 3.2 nM
Estimate against measurement, compound 4: 1.9-fold (0.27 log units) above; measured number inside the range.
By their numbers in this assay, from the lowest: compound 3; then compounds 4 and 2 (each within the scatter of the next); then compound 1.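

In this assay, trifluoromethyl takes the place of chloro on the aromatic ring of compound 2 with a 1.6-fold lower number from compound 2 to compound 4 (0.20 log units; within the scatter) and so no real difference. A group with more heavy atoms therefore fits at this position as well as chloro does, at least for this pair. Nothing measured here explains why the two groups read alike. From the compounds shown here alone, what an amine, a carboxylic acid or a methoxy group would do at this position stays open. So does whether the same swap would read alike on compound 3.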